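A Methyl on the Benzyl Amide of Compound 3

The source may hold more compounds than are shown below. What is called first, only, known or untested is meant among the compounds shown, and "the series" means these compounds.

- compound 1 `CCCCNC(=O)CCCOc1ccc(C(=O)c2c(CCCC)oc3ccccc23)cc1`: 24600 nM
- compound 2 `CCCCc1oc2ccccc2c1C(=O)c1ccc(OCCCC(=O)N2CCCCC2)cc1`: 16600 nM
- compound 3 `CCCCc1oc2ccccc2c1C(=O)c1ccc(OCCCC(=O)NCc2ccccc2)cc1`: 15800 nM

These three amides were tested in a functional assay on U-937 cells (Homo sapiens) for antiproliferative activity, read by MTT assay, with a stated time of 24 h; a lower number here means a stronger inhibitor, a higher number a weaker inhibitor. Compound 3, at 15800 nM, cannot be separated from the other two: the data show a 1.6-fold lower number from compound 1 to compound 3 (0.19 log units; within the scatter) and a 1.1-fold lower number from compound 2 to compound 3 (0.02 log units; within the scatter). Compound 4 `CCCCc1oc2ccccc2c1C(=O)c1ccc(OCCCC(=O)N[C@@H](C)c2ccccc2)cc1` extends compound 3 with one small change, (methyl in place of hydrogen on a saturated chain carbon bound to an amide-type nitrogen and an aromatic carbon). Methyl takes the place of hydrogen on a saturated chain carbon bound to an amide-type nitrogen and an aromatic carbon, so benzylamino becomes (1-phenylethyl)amino.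

Going by the values given here, no measured step places a methyl at this carbon, so the evidence is only indirect. The nearest guide is the set of changes to the group on the amide nitrogen, which includes a 1.5-fold lower number from compound 1 to compound 2 (0.17 log units; within the scatter) as well as the two steps to compound 3. All three of these larger exchanges stayed within the scatter in this assay, so a single added methyl is not expected to produce a clear shift in either direction. The estimate therefore means a 1.1-fold lower number from compound 3 to compound 4 (0.02 log units; within the scatter), an expected step that does not go beyond the scatter. For compound 4 the expected value is 15000 nM, with an estimated range from 8000 nM to 28000 nM.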

Compound 4, half-maximal inhibitory concentration: 22400 nM
Beside the measured number, compound 4's estimate is 1.5-fold (0.17 log units) below it, and the stated range covers the measured number.
By their numbers in this assay, from the lowest: compounds 3, 2, 4 and 1 (each within the scatter of the next).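

In this assay, placing methyl in place of hydrogen on the saturated chain carbon bound to an amide-type nitrogen and an aromatic carbon gives a 1.4-fold higher number from compound 3 to compound 4 (0.15 log units; within the scatter), so this position now has a direct reading, and this single added carbon, like the larger exchanges on the amide nitrogen, stays within the scatter. The comparisons with the other two amides read the same way, with a 1.3-fold higher number from compound 2 to compound 4 (0.13 log units; within the scatter) and a 1.1-fold lower number from compound 1 to compound 4 (0.04 log units; within the scatter), so (1-phenylethyl)amino joins butylamino, piperidin-1-yl and benzylamino as a set of four amide groups that this assay does not separate. Nothing available here offers an explanation for these numbers.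

Compound 4 carries one stated spatial arrangement at the methyl-bearing carbon, and the compounds shown leave open how its mirror-image form would read in this assay. They also leave open whether an ethyl group in place of the methyl, or an amine or a carboxylic acid on the phenyl of the 1-phenylethyl group, would give a step beyond the scatter.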